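A few compounds are considered here, and "the series" means these few. Any claim that something is new, unique, unknown or untested is made for them only; others in the source may bear on it.

Of the compounds shown here, three have so far been tested in a functional assay on NPC-TW01 cells (Homo sapiens) for antiproliferative activity, read by MTT assay, with a stated time of 72 h; on this read-out higher numbers stand for weaker inhibition of growth and lower numbers for stronger inhibition of growth. Compound 1, `O=C(COc1ccc2oc(-c3ccccc3)cc(=O)c2c1)Nc1ccc(F)cc1`, gives 740 nM in this assay, and compound 2, `COc1ccc(NC(=O)COc2ccc3oc(-c4ccccc4)cc(=O)c3c2)cc1`, gives 710 nM in this assay. Compound 3, `O=C(COc1ccc2c(=O)c(-c3ccccc3)coc2c1)Nc1ccc(F)cc1`, is built from the same atoms as compound 1 joined differently; the difference between the two cores is not broken down here. In this assay compound 3 gives 550 nM, a number that sits within the scatter of the other two, so no order among the three can be read from these data.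

Among the measured compounds shown here, the one change measured on its own is methoxy in place of fluoro on an aromatic carbon, and it made a step of a 1.0-fold lower number from compound 1 to compound 2 (0.02 log units; within the scatter), which is to say no movement that can be separated from the noise of the measurement.

Compound 4, `COc1ccc(NC(=O)COc2ccc3c(=O)c(-c4ccccc4)coc3c2)cc1`, has not yet been measured in this assay. It differs from compound 3 by methoxy in place of fluoro on an aromatic carbon. The place where this change is made reads word for word the same as the place of the change from compound 1 to compound 2, so it is the same change, now applied to the core of compound 3. Because the earlier step was a 1.0-fold lower number from compound 1 to compound 2 (0.02 log units; within the scatter), the expected step is a 1.0-fold lower number from compound 3 to compound 4 (0.02 log units; within the scatter). Compound 4 is therefore estimated at 530 nM in this assay, with a likely range from 270 nM to 1100 nM.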

Compound 4, concentration for 50% growth inhibition: 6700 nM
Beside the measured number, compound 4's estimate is 13-fold (1.10 log units) below it, and the stated range ends below it.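

In this assay, methoxy in place of fluoro on an aromatic carbon did not carry over from one core to the other, and the size of its step depended on the core that bore it: the same change on two cores in this assay, a 1.0-fold lower number (0.02 log units; within the scatter) from compound 1 to compound 2 and a 12-fold higher number (1.09 log units; beyond the scatter) from compound 3 to compound 4, 13-fold (1.10 log units) apart, beyond the scatter of two such steps. The change from 4-fluorophenyl to 4-methoxyphenyl made a 12-fold higher number from compound 3 to compound 4 (1.09 log units; beyond the scatter), which on this read-out stands for weaker inhibition of growth, so a flat step on one core gave no safe guide to the same change on the other. This rests on a single pair for each core, and it does not show which difference between the two cores lies behind the gap, nor whether the gap extends to any other change in this series.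

The compounds shown leave open whether the large step belongs to methoxy itself, since it is unknown whether chloro, hydroxy or ethoxy at the same place on the core of compound 3 would stay close to compound 3 or fall close to compound 4. They also leave open whether the core of compound 1 would stay as flat with a dimethylamino group or a carboxylic acid at that place.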